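Urea tail change on the trifluoromethyl anilino compound

The compounds below may be only part of what the source reports. "The series", "measured", "known", "first", "only" and "open" are said of these compounds alone.

Compound 1 `CCN(CC)Cc1ccc(NC(=O)Nc2ccc3ncnc(Nc4cccc(C(F)(F)F)c4)c3c2)cc1` gives 3980 nM in a functional assay on A-431 cells (Homo sapiens) for antiproliferative activity, read by MTT assay, with a stated time of 72 h (on this read-out lower numbers stand for stronger inhibition and higher numbers for weaker inhibition), and stands as the higher of the two numbers in hand; compound 2 `C#Cc1cccc(Nc2ncnc3ccc(NC(=O)Nc4ccc(CN(CC)CC)cc4)cc23)c1` gives 1240 nM, and the step of a 3.2-fold lower number from compound 1 to compound 2 (0.51 log units; beyond the scatter) concerns only the anilino substituent. Compound 3 `COc1ccc(NC(=O)Nc2ccc3ncnc(Nc4cccc(C(F)(F)F)c4)c3c2)cc1` differs from compound 1 by methoxy in place of (diethylamino)methyl on an aromatic carbon. For the measured compounds named here, no measured step touches this part of the molecule, so neither size nor direction of the step in this assay can be read from the series. Compound 3 is therefore expected to stay near the level of its parent, with a wide range, a 1.3-fold higher number from compound 1 to compound 3 (0.10 log units; within the scatter). Compound 3 is estimated at 5000 nM, spanning 1500 nM to 16000 nM.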

Compound 3, half-maximal inhibitory concentration: 4950 nM
For compound 3 the middle estimate is 1.0-fold (0.00 log units) above the measured one; low and high end bracket the measured number.
By their numbers in this assay, from the lowest: compound 2; then compounds 1 and 3 (each within the scatter of the next).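

In this assay the urea tail position now has its first reading: methoxy in place of (diethylamino)methyl gives a 1.2-fold higher number from compound 1 to compound 3 (0.09 log units; within the scatter) and stays within the scatter. On the trifluoromethyl anilino scaffold, the 4-((diethylamino)methyl)phenyl tail can therefore give way to 4-methoxyphenyl, with the amine removed, without a difference that can be read. No supporting data explain this result.

Going by these compounds, it remains open whether a carboxylic acid or a longer chain at this position would read the same. On these data alone, the methoxy tail on the ethynyl anilino core of compound 2 is also open.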